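The compounds below may be only part of what the source reports. "The series", "measured", "known", "first", "only" and "open" are said of these compounds alone.

In an ADME assay for permeability, using PAMPA, with a stated time of 4 h, at pH 7.4, tested at 100 uM (a lower number here means that the compound crosses the layer more slowly, a higher number that the compound crosses the layer faster), compound 1 `Cc1ccc(-c2cc3nc(C)c(C(OC(C)(C)C)C(=O)O)c(-c4cc(F)c5c(c4C)CCCO5)n3n2)cc1` gives 492 nm/s as its reading, compound 2 `Cc1nc2cc(-c3ccc(OCc4ccccc4)cc3)nn2c(-c2cc(F)c3c(c2C)CCCO3)c1C(OC(C)(C)C)C(=O)O` gives 313 nm/s as its reading and compound 3 `COc1ccccc1-c1cccc(-c2cc3nc(C)c([C@H](OC(C)(C)C)C(=O)O)c(-c4cc(F)c5c(c4C)CCCO5)n3n2)c1` gives 765 nm/s on the same scale. The numbers for compound 3 and compound 1 lie within the scatter of each other, so the two cannot be ranked. Compound 2 stands lower than compound 3 by more than the scatter.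

Compound 4 `COc1ccc(-c2cccc(-c3cc4nc(C)c([C@H](OC(C)(C)C)C(=O)O)c(-c5cc(F)c6c(c5C)CCCO6)n4n3)c2)cn1` has not yet been measured. It carries 6-methoxypyridin-3-yl in place of 2-methoxyphenyl on an aromatic carbon, and the counted difference from compound 3 reads 6-methoxypyridin-3-yl in place of 2-methoxyphenyl on an aromatic carbon in full.

Among the compounds with values here, no measured step makes this exchange. Within the data shown here, the only step that changes one place is a 1.6-fold lower number from compound 1 to compound 2 (0.20 log units; within the scatter) and it lies within the scatter, with benzyloxy in place of methyl on an aromatic carbon. It is a different exchange and offers only loose guidance, yet it gives no reason to expect a large move here. The expected change is therefore small, with an estimated 1.3-fold lower number from compound 3 to compound 4 (0.11 log units; within the scatter) as a slight fall that stays within the scatter. For compound 4 the estimated value is 600 nm/s with 300 nm/s to 1100 nm/s as the expected range.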

Compound 4, apparent permeability: 514 nm/s
Beside the measured number, compound 4's estimate is 1.2-fold (0.07 log units) above it, within the range that was stated.
By their numbers in this assay, from the lowest: compounds 2, 1, 4 and 3 (each within the scatter of the next, the first and the last beyond it).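

In this assay, the exchange on an aromatic carbon of a six-membered aromatic ring of carbon only, meta to a large group, gives a 1.5-fold lower number from compound 3 to compound 4 (0.17 log units; within the scatter). The earlier compounds shown here offered only a different exchange, a 1.6-fold lower number from compound 1 to compound 2 (0.20 log units; within the scatter), with benzyloxy in place of methyl, whereas this step shows that 6-methoxypyridin-3-yl can take the place of 2-methoxyphenyl, with 8 heavy atoms in each group, without a change that stands clear of the scatter, even though the ring now holds 1 hetero atom and the group counts 2 hydrogen-bond acceptors rather than 1. No measurement of any property of these groups bears on the result, so the step can be reported but not explained.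

The compounds shown leave open whether the ring nitrogen or the altered placement of the methoxy group matters more in this exchange, a question that a 4-methoxyphenyl group at the same place would help to separate. They also leave open how the reading would respond to a group of a different kind there, such as an amine or a carboxylic acid.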